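Guanidine with pyridinylmethyl in place of furoyl thiourea

This account rests on a few compounds, and the source may have more. Where it says the series, first, only, none or still open, it means among the compounds named here.

Compound 1 `CN(c1cc2ncc(=O)[nH]c2cc1NC(=S)NC(=O)c1cccc(C(F)(F)F)c1)C1CCCCC1`: 31500 nM
Compound 2 `CN(c1cc2ncc(=O)[nH]c2cc1NC(=S)NC(=O)c1ccco1)C1CCCCC1`: 17300 nM
Compound 3 `CN(c1cc2ncc(=O)[nH]c2cc1NC(=S)NC(=O)c1ccc(Cl)nc1)C1CCCCC1`: 34500 nM

In an ADME assay on Huh-7 cells (Homo sapiens) for cytotoxicity (a lower number here means a stronger inhibitor, a higher number a weaker inhibitor), compound 2 gives the lower of the three numbers, yet a 1.8-fold lower number from compound 1 to compound 2 (0.26 log units; within the scatter) and a 2.0-fold higher number from compound 2 to compound 3 (0.30 log units; within the scatter) are both within the scatter, as is a 1.1-fold higher number from compound 1 to compound 3 (0.04 log units; within the scatter), so the three measured compounds cannot be told apart. Compound 4 `CN(c1cc2ncc(=O)[nH]c2cc1NC(=N)NCc1ccccn1)C1CCCCC1` carries a group of 10 heavy atoms (7 carbon, 3 nitrogen; one six-membered aromatic ring with 1 hetero atom) in place of a group of 10 heavy atoms (6 carbon, 1 nitrogen, 2 oxygen, 1 sulfur; one five-membered aromatic ring with 1 hetero atom), on a nitrogen on an aromatic ring. For the measured compounds named here, none of the measured steps touches this position; they only exchange the group on the carbonyl carbon and all stay within the scatter, so there is no step that bears on the change from compound 2 to compound 4. Compound 4 is therefore expected to give 25000 nM, between 8000 nM and 80000 nM, a step of a 1.4-fold higher number from compound 2 to compound 4 (0.16 log units; within the scatter) that is estimated to stay within the scatter.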

Compound 4, half-maximal inhibitory concentration: 48600 nM
Beside the measured number, compound 4's estimate is 1.9-fold (0.29 log units) below it; the measured number falls inside the stated range.
By their numbers in this assay, from the lowest: compounds 2, 1, 3 and 4 (each within the scatter of the next, the first and the last beyond it).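

In this assay, for the compounds shown here, the exchange on the nitrogen on an aromatic ring gives a 2.8-fold higher number from compound 2 to compound 4 (0.45 log units; beyond the scatter), the only step here beyond the scatter, whereas the steps on the carbonyl carbon all stayed within it. This position therefore moves the number modestly, at least between compound 2 and compound 4. No measurement given here accounts for this step.

The furoyl thiourea and the guanidine with pyridinylmethyl differ in several parts at once, so the part responsible remains unresolved. As far as these compounds go, how a simple amine or a carboxylic acid at this position would read also stays open.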